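Working notes: ring replacement on the shared core, EP4 binding

This account rests on a few compounds, and the source may have more. Where it says the series, first, only, none or still open, it means among the compounds named here.

Measured so far:
compound 1 `Cc1oc(C(=O)O)cc1COc1ccc(-c2ccc(C#N)cc2)cc1` — 1500 nM
compound 2 `Cc1oc(C(=O)O)cc1COc1ccc(-c2nnco2)cc1` — > 10000 nM

In an assay on cells for displacement of a labelled ligand from prostaglandin E2 receptor EP4 subtype (Homo sapiens), read by scintillation counting (on this read-out higher numbers stand for weaker inhibition and lower numbers for stronger inhibition), compound 1 gives 1500 nM. For compound 2 this assay reports only a limit, > 10000 nM, so compound 2 stands at the weak end of the numbers shown without a defined value; see (the limit of > 10000 nM in this assay, at which 1 of the 2 values shown sits). Within the data shown here, the step of an at least 6.6-fold higher number from compound 1 to compound 2 (0.82 log units; beyond the scatter) is the only measured change at this position and it weakened binding.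

Compound 3 `Cc1oc(C(=O)O)cc1COc1ccc(-c2ccccc2)cc1` is the next member: phenyl in place of 1,3,4-oxadiazol-2-yl on an aromatic carbon. This returns a six-membered carbon-only ring, as in compound 1, but without the nitrile of compound 1. The step of an at least 6.6-fold higher number from compound 1 to compound 2 (0.82 log units; beyond the scatter) bears on it directly: undoing the oxadiazole is expected to recover part of that loss, while the missing nitrile leaves compound 3 estimated short of compound 1. The expected step is an at least 3.3-fold lower number from compound 2 to compound 3 (0.52 log units; beyond the scatter), toward stronger binding. Compound 3 is estimated at 3000 nM, with a range from 800 nM to 12000 nM.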

Compound 3, inhibition constant: 420 nM
The estimate for compound 3 lay 7.1-fold (0.85 log units) above the measured number; the whole stated range lies above it.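

At this aromatic carbon, para to a large group, a bare phenyl ring is the strongest of the three groups shown, and the nitrile of compound 1 brings no gain: hydrogen in place of cyano gives a 3.6-fold lower number from compound 1 to compound 3 (0.55 log units; beyond the scatter). Phenyl in place of 1,3,4-oxadiazol-2-yl gives an at least 23-fold lower number from compound 2 to compound 3 (1.37 log units; beyond the scatter). Compound 2 carries only a limit, so that step has a bound and no defined size: the limit of > 10000 nM in this assay, at which 1 of the 3 values shown sits.

The 1,3,4-oxadiazol-2-yl and phenyl rings differ in both ring size and hetero atoms, and the compounds shown do not separate the two. Also open, as far as these compounds go, is whether a pyridine ring in place of phenyl would keep the binding of compound 3, and whether a methoxy group or a fluorine atom on the phenyl ring would fall closer to hydrogen or to cyano.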